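This account rests on a few compounds, and the source may have more. Where it says the series, first, only, none or still open, it means among the compounds named here.

So far, three compounds have numbers in a functional assay on P388 cells (Mus musculus) for cytotoxicity; on this read-out higher numbers stand for weaker inhibition and lower numbers for stronger inhibition:
- compound 1 `COc1ccc(C[C@H]2C(=O)N[C@@H](C)C(=O)N(C)[C@H]3Cc4ccc(cc4)Oc4cc(ccc4OC)C[C@@H](C(=O)N[C@H](C)C(=O)N[C@@H](CSC(C)=O)C(=O)N2C)N(C)C3=O)cc1` gives 9.77 nM in this series
- compound 2 `COc1ccc(C[C@H]2C(=O)N[C@@H](C)C(=O)N(C)[C@H]3Cc4ccc(cc4)Oc4cc(ccc4OC)C[C@@H](C(=O)N[C@H](C)C(=O)N[C@@H](CC(=O)O)C(=O)N2C)N(C)C3=O)cc1` gives 1200 nM in this series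
- compound 3 `CCCN1C(=O)[C@@H](C)NC(=O)[C@@H]2Cc3ccc(OC)c(c3)Oc3ccc(cc3)C[C@@H](C(=O)N2C)N(C)C(=O)[C@H](C)NC(=O)[C@H](Cc2ccc(OC)cc2)N(C)C(=O)[C@@H]1C` gives 3.98 nM in this series

Compound 3 holds the lowest number of the three, and both other compounds lie beyond the scatter from it. Compound 4 `COc1ccc(C[C@H]2C(=O)N[C@@H](C)C(=O)N(C)[C@H]3Cc4ccc(cc4)Oc4cc(ccc4OC)C[C@@H](C(=O)N[C@H](C)C(=O)N(CC=C(C)C)[C@@H](C)C(=O)N2C)N(C)C3=O)cc1` departs from compound 3 by one change, 2-methylprop-1-en-1-yl in place of ethyl on a saturated chain carbon bound to an amide-type nitrogen in a ring in which 2-methylprop-1-en-1-yl takes the place of ethyl on a saturated chain carbon bound to an amide-type nitrogen in a ring. Read one bond further out, propyl becomes 3-methylbut-2-en-1-yl.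

Among the measured compounds shown here, the only measured step, a 120-fold higher number from compound 1 to compound 2 (2.09 log units; beyond the scatter) is large, but it swaps other groups at another place. For the measured compounds named here, it therefore bears only weakly on this change, and no measured step touches this place. A small step towards a higher number is expected in this assay with the wide range reflecting that gap. The estimated step is a 2.0-fold higher number from compound 3 to compound 4 (0.30 log units; within the scatter) at about the edge of the scatter. For compound 4 the expected value is 8 nM within an estimated range from 2 nM to 40 nM in this read-out.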

Compound 4, half-maximal inhibitory concentration: 6.92 nM
Compound 4: middle estimate off by 1.2-fold (0.06 log units), on the high side; measured number inside the range.
By their numbers in this assay, from the lowest: compounds 3, 4 and 1 (each within the scatter of the next, the first and the last beyond it); then compound 2.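

In this assay, replacing ethyl with 2-methylprop-1-en-1-yl gives a 1.7-fold higher number from compound 3 to compound 4 (0.24 log units; within the scatter), the first step read at this place, on a saturated chain carbon bound to an amide-type nitrogen in a ring. It shows that the propyl of compound 3 can give way to the 3-methylbut-2-en-1-yl of compound 4, with its double bond outside aromatic rings, and the number stays within the scatter, unlike the large step seen at the other place. No measured evidence here offers a reason for this result.

The compounds shown leave open whether the double bond matters at all, as 3-methylbutyl would test. They also leave open how this place would respond to an amine or a carboxylic acid at the end of the chain.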